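The source may hold more compounds than are shown below. What is called first, only, known or untested is meant among the compounds shown, and "the series" means these compounds.

Measured compounds:
compound 1, `c1ccc2c(c1)CN[C@@H](CN(CCCCNCC1CCCCC1)[C@H]1CCCc3cccnc31)C2`: 158 nM
compound 2, `CC(C)(CN)CCN(C[C@H]1Cc2ccccc2CN1)[C@H]1CCCc2cccnc21`: 69 nM
compound 3, `CC(C)(CCN(C[C@H]1Cc2ccccc2CN1)[C@H]1CCCc2cccnc21)CNCC1CCOCC1`: 43.8 nM

In a functional assay on cells for antagonist activity at C-X-C chemokine receptor type 4 (Homo sapiens), read by fluorescence and calcium flux, with stated times of 25 min and 90 s (a higher number here means a weaker inhibitor, a lower number a stronger inhibitor), compound 3 gives 43.8 nM, the lowest number of the three, with a 1.6-fold lower number from compound 2 to compound 3 (0.20 log units; within the scatter) and a 3.6-fold lower number from compound 1 to compound 3 (0.56 log units; beyond the scatter). Compound 4, `CC(C)(CCN(C[C@H]1Cc2ccccc2CN1)[C@H]1CCCc2cccnc21)CNC1CCC(F)(F)CC1`, differs from compound 3 by 4,4-difluorocyclohexyl in place of (oxan-4-yl)methyl on an amine nitrogen. For the measured compounds named here, the one step at this amine nitrogen, a 1.6-fold lower number from compound 2 to compound 3 (0.20 log units; within the scatter), shows that a ring-bearing substituent there changed little; a 2.3-fold lower number from compound 1 to compound 2 (0.36 log units; beyond the scatter) concerns the chain carbon and bears only indirectly. Nothing here shows that swapping one six-membered non-aromatic ring for another at this nitrogen should move the number beyond the scatter. Compound 4 is therefore expected to sit near compound 3 in this assay, with a 1.0-fold higher number from compound 3 to compound 4 (0.01 log units; within the scatter). The estimate for compound 4 is 45 nM, within a range of 18 nM to 120 nM.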

Compound 4, half-maximal inhibitory concentration in the C-X-C chemokine receptor type 4 assay: 168 nM
For compound 4 the middle estimate is 3.7-fold (0.57 log units) below the measured one, and the stated range ends below it.
By their numbers in the C-X-C chemokine receptor type 4 assay, from the lowest: compounds 3 and 2 (each within the scatter of the next); then compounds 1 and 4 (each within the scatter of the next).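

For the compounds shown here, at this amine nitrogen, the earlier compounds showed only that hydrogen and (oxan-4-yl)methyl lie within the scatter of each other, but in the C-X-C chemokine receptor type 4 assay compound 4 with 4,4-difluorocyclohexyl gives 168 nM with a 3.8-fold higher number from compound 3 to compound 4 (0.58 log units; beyond the scatter) and a 2.4-fold higher number from compound 2 to compound 4 (0.39 log units; beyond the scatter) so the number here does depend on the substituent. The change removes the ring oxygen, brings in fluorine and sets the ring directly on the nitrogen, so the step cannot be assigned to any one of these. No evidence at hand accounts for the step.

Cyclohexyl or (4,4-difluorocyclohexyl)methyl on this nitrogen would separate these changes. In a physicochemical assay for permeability, using PAMPA, with a stated time of 4 h, at pH 7.4, tested at 100 uM (on this read-out higher numbers stand for higher permeability and lower numbers for lower permeability), compound 3 is "not determined" (no result reported) and compound 4 gives 22 nm/s so the two cannot be compared.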